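A few compounds are considered here, and "the series" means these few. Any claim that something is new, unique, unknown or untested is made for them only; others in the source may bear on it.

Working notes on the series. Three compounds of the shared core have numbers in an ADME assay on BHK cells (Mesocricetus auratus) for cytotoxicity, read by MTT assay, with a stated time of 96 h; a higher number here means that more compound is tolerated, a lower number that less compound is tolerated. Compound 1 `CCC(=O)Nc1ccc(-c2nc3cc(C(F)(F)F)ccc3[nH]2)cc1` gives 100000 nM. Compound 2 `CCN(CC)CC(=O)Nc1ccc(-c2nc3cc(C(F)(F)F)ccc3[nH]2)cc1` gives 23000 nM, and compound 3 `Fc1ccc(-c2nc3cc(C(F)(F)F)ccc3[nH]2)cc1` gives 25000 nM. Among these, compound 3 holds the second highest number; its nearest neighbour is compound 2, a gap within the scatter, and its furthest is compound 1, which stands beyond the scatter above it. The two measured steps of size are a 4.3-fold lower number from compound 1 to compound 2 (0.64 log units; beyond the scatter) and a 4.0-fold lower number from compound 1 to compound 3 (0.60 log units; beyond the scatter); the step of a 1.1-fold higher number from compound 2 to compound 3 (0.04 log units; within the scatter) is within the scatter.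

Compound 4 `O=C(CCl)Nc1ccc(-c2nc3cc(C(F)(F)F)ccc3[nH]2)cc1` is not yet measured. It differs from compound 3 in one place: ((chloromethyl)carbonyl)amino in place of fluoro on an aromatic carbon. The step bearing most on this change is a 4.0-fold lower number from compound 1 to compound 3 (0.60 log units; beyond the scatter), which runs the other way, from propanoylamino to fluoro; read in reverse it points to a higher number when fluoro gives way to ((chloromethyl)carbonyl)amino, which shares the carbonylamino part of propanoylamino. Against that, a 4.3-fold lower number from compound 1 to compound 2 (0.64 log units; beyond the scatter) shows that what sits on a saturated chain carbon bound to a carbonyl carbon can pull the number back down, and chloromethyl at that carbon has not been measured. Compound 4 is therefore expected to show a modest rise, a 2.2-fold higher number from compound 3 to compound 4 (0.34 log units; beyond the scatter). The estimate for compound 4 in this assay is 55000 nM, with a range from 20000 nM to 130000 nM.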

Compound 4, half-maximal cytotoxic concentration: 22000 nM
Estimate against measurement, compound 4: 2.5-fold (0.40 log units) above, within the range that was stated.
By their numbers in this assay, from the lowest: compounds 4, 2 and 3 (each within the scatter of the next); then compound 1.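

In this assay, ((chloromethyl)carbonyl)amino in place of fluoro on an aromatic carbon, para to a large group, gives a 1.1-fold lower number from compound 3 to compound 4 (0.06 log units; within the scatter) and so no readable step, which shows that carrying the carbonylamino part at this position is not enough to set a compound apart from compound 3. At the saturated chain carbon bound to a carbonyl carbon, chloro in place of diethylamino gives a 1.0-fold lower number from compound 2 to compound 4 (0.02 log units; within the scatter) and cannot be told from it, while chloro in place of methyl gives a 4.5-fold lower number from compound 1 to compound 4 (0.66 log units; beyond the scatter) in the same assay. Among the amides, compound 1 therefore stands alone, and the group at that chain carbon, not the carbonylamino part, separates it from compound 2 and compound 4. Nothing here gives a measured reason for these steps.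

As far as these compounds go, it remains open whether the higher number of compound 1 is particular to methyl at that chain carbon or extends to a longer chain, a hydroxyl or a methoxy there. A primary amine or a carboxylic acid at the same carbon would show whether compound 2 and compound 4 mark a general level for substituted chains.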